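The source may report more compounds than this note shows. Statements on the series, on what has been measured and on what is new or still open speak of the compounds shown alone.

Compound 1 `CC(C)(C)c1ccc(C#N)cc1NC(=O)Nc1cccnc1`: 25700000 nM; compound 2 `CC(C)(C)c1ccc(C#N)cc1NC(=O)Nc1cncnc1`: 12400000 nM.

In a functional assay (aorta) for inhibition, with Rattus norvegicus as the target (on this read-out lower numbers stand for stronger inhibition and higher numbers for weaker inhibition), compound 1 gives 25700000 nM, the highest of the two numbers; its nearest neighbour is compound 2, with a 2.1-fold lower number from compound 1 to compound 2 (0.32 log units; beyond the scatter). Compound 3 `N#Cc1ccc(-c2ccccc2)c(NC(=O)Nc2cccnc2)c1` differs from compound 1 by phenyl in place of tert-butyl on an aromatic carbon. Among the compounds with values here, no measured step touches this position: the only step known, from compound 1 to compound 2, changes the ring on the urea nitrogen, so it gives no guide here. Compound 3 is therefore expected to stay close to compound 1, with a 1.3-fold lower number from compound 1 to compound 3 (0.11 log units; within the scatter). The estimate for compound 3 is 20000000 nM, within 5000000 nM to 80000000 nM.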

Compound 3, half-maximal inhibitory concentration: 22800000 nM
The estimate for compound 3 lay 1.1-fold (0.06 log units) below the measured number, within the range that was stated.
By their numbers in this assay, from the lowest: compounds 2, 3 and 1 (each within the scatter of the next, the first and the last beyond it).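

Placing phenyl in place of tert-butyl on this aromatic carbon gives, in this assay, a 1.1-fold lower number from compound 1 to compound 3 (0.05 log units; within the scatter). This position, para to a cyano group, therefore takes a ring of carbon as readily as a branched group, with no difference that stands out from the scatter. No measurement available here explains this result.

Going by these compounds, whether an amine, a hydroxyl group or a carboxylic acid on this carbon would move the number remains open. So does whether phenyl would behave the same way alongside the pyrimidin-5-yl group of compound 2.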